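The compounds below may be only part of what the source reports. "The series", "measured", "known", "first", "only" and "open" are said of these compounds alone.

In an ADME assay on MDCK cells (Canis lupus familiaris) for permeability, read by LC-MS, with a stated time of 90 min, tested at 2 uM (a lower number here means that the compound crosses the layer more slowly, a higher number that the compound crosses the layer faster), compound 1 `Cc1cc(C)c(CN2CCc3c(Cl)cc([C@H](CO)[C@H]4CCCO4)c(Cl)c3C2=O)c(=O)[nH]1` gives 4.1 10^-6 cm/s and compound 2 `Cc1cc(C)c(CN2CCc3c(Cl)cc([C@H](CO)[C@@H]4CCCO4)c(Cl)c3C2=O)c(=O)[nH]1` gives 14.6 10^-6 cm/s, so compound 2 holds the higher of the two numbers. The measured change is a 3.6-fold higher number from compound 1 to compound 2 (0.55 log units; beyond the scatter), due to the fact that compounds 1 and 2 differ only in the configuration as drawn. Compound 3 `Cc1cc(C)c(CN2CCc3c(Cl)cc([C@@H](CO)[C@@H]4CCOC4)c(Cl)c3C2=O)c(=O)[nH]1` keeps the shared core and has the same atoms as compound 2, joined differently: a group of 8 heavy atoms (6 carbon, 2 oxygen; one five-membered non-aromatic ring with 1 hetero atom) in place of a group of 8 heavy atoms (6 carbon, 2 oxygen; one five-membered non-aromatic ring with 1 hetero atom), on an aromatic carbon, on an aromatic carbon. Going by the values given here, that single step is the only guide. It shows a change of configuration alone moving this assay beyond the scatter, but it does not test a change in how the atoms are joined. With compound 1 at 4.1 10^-6 cm/s as the only other reference, a modest fall is expected rather than a rise. The expected change is a 1.8-fold lower number from compound 2 to compound 3 (0.26 log units; within the scatter). Compound 3 is estimated at 8 10^-6 cm/s, with an expected range from 3 10^-6 cm/s to 20 10^-6 cm/s.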

Compound 3, apparent permeability: 3 10^-6 cm/s
Beside the measured number, compound 3's estimate is 2.7-fold (0.43 log units) above it, and the stated range covers the measured number.
By their numbers in this assay, from the lowest: compounds 3 and 1 (each within the scatter of the next); then compound 2.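

In this assay, joining the same atoms differently within the group on the aromatic carbon also moves the number beyond the scatter, giving a 4.9-fold lower number from compound 2 to compound 3 (0.69 log units; beyond the scatter). Measured against the other configuration, the same kind of change gives a 1.4-fold lower number from compound 1 to compound 3 (0.14 log units; within the scatter), so at this position compound 3 stays within the scatter of compound 1 while lying clearly apart from compound 2. The compounds offer no account of the fall to compound 3 itself, and the one account available concerns another pair: the fact that compounds 1 and 2 differ only in the configuration as drawn.

The compounds shown leave open how far the number for compound 3 depends on its drawn configuration rather than on how the ring is joined. They also leave open whether a morpholine ring or an open methoxyethyl chain on this aromatic carbon would read nearer to compound 2 or to compound 3.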